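This account rests on a few compounds, and the source may have more. Where it says the series, first, only, none or still open, it means among the compounds named here.

Of the compounds shown here, three have so far been tested in a functional assay on HCT-116 cells (Homo sapiens) for inhibition, read by MTT assay, with a stated time of 24 h, tested at 5 uM; on this read-out lower numbers stand for less inhibition of growth and higher numbers for more inhibition of growth at the one concentration tested. Compound 1 `CS(=O)(=O)c1ccc(-c2cnc3[nH]cc(-c4nnc(-c5ccccc5)o4)c(=O)c3c2)cc1` gives 8.6% in this assay. Compound 2 `CS(=O)(=O)c1ccc(-c2cnc3[nH]cc(-c4nnc(-c5cccnc5)o4)c(=O)c3c2)cc1` gives 9.26% in this assay. Compound 3 `O=c1c(-c2nnc(-c3ccc(Cl)cc3)o2)c[nH]c2ncc(-c3cccnc3)cc12` gives 15.9% in this assay. Compound 2 and compound 1 differ in one place, (phenyl in place of pyridin-3-yl on an aromatic carbon), and this change made a number 0.7 percentage points lower from compound 2 to compound 1 (within the scatter). The difference between the core of compound 2 and the core of compound 3 is not broken down here.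

Compound 4 `O=c1c(-c2nnc(-c3ccc(Cl)cc3)o2)c[nH]c2ncc(-c3ccccc3)cc12` has not yet been measured in this assay. It differs from compound 3 by phenyl in place of pyridin-3-yl on an aromatic carbon. Within the data shown here, this is the same kind of change as the one from compound 2 to compound 1, but not the same: in compound 2 the group sits on an aromatic carbon of a five-membered aromatic ring with two nitrogen and one oxygen, next to the ring nitrogen and next to the ring oxygen, whereas in compound 3 it sits on an aromatic carbon of a six-membered aromatic ring with one nitrogen, part of a fused or bridged system of two rings, two atoms from the ring nitrogen, meta to a fused ring and para to a fused ring.

The expected step in this assay is a number 0.9 percentage points lower from compound 3 to compound 4 (within the scatter), because the earlier step of the same kind, a number 0.7 percentage points lower from compound 2 to compound 1 (within the scatter), stayed within the scatter. For compound 4 the estimated value is 15%, with a likely range from 5% to 25%.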

Compound 4, percent growth inhibition at one concentration: 12.3%
Estimate against measurement, compound 4: 2.7 percentage points above; low and high end bracket the measured number.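

In this assay, putting phenyl in place of pyridin-3-yl on the core of compound 3 gives a number 3.6 percentage points lower from compound 3 to compound 4 (within the scatter). Set beside the earlier example of this swap, the result reads the same on both cores: the same change on two cores in this assay, a number 0.7 percentage points lower (within the scatter) from compound 2 to compound 1 and a number 3.6 percentage points lower (within the scatter) from compound 3 to compound 4, 2.9 percentage points apart, within the scatter of two such steps This shows that, in these two pairs, removing the ring nitrogen of the pyridin-3-yl group produced no step that can be told apart from ordinary repeat-to-repeat variation, but it does not prove that the two groups are equivalent, and two pairs, with the swap in a different place in each, are too few to make a rule for the whole series.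

The compounds shown leave open what a group of a different kind, such as an amine, a carboxylic acid or a longer chain, would do in place of phenyl or pyridin-3-yl on the aromatic carbon of the six-membered ring with one nitrogen. They also leave open whether phenyl and pyridin-3-yl would still fall within the scatter of each other on a third core or at another concentration.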